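The compounds below may be only part of what the source reports. "The series", "measured", "known", "first", "only" and "open" are said of these compounds alone.

Measured so far in a functional assay on NCI-H460 cells (Homo sapiens) for inhibition, read by sulforhodamine B assay, with a stated time of 48 h; a lower number here means a stronger inhibitor of growth, a higher number a weaker inhibitor of growth:
- compound 1 `COC(=O)c1sc2cc(C#Cc3ccc(N)cc3)cnc2c1N` gives 8900 nM
- compound 2 `COC(=O)c1sc2cc(C#Cc3ccsc3)cnc2c1N` gives 24800 nM
- compound 3 `COC(=O)c1sc2cc(C#Cc3cccc(OC)c3)cnc2c1N` gives 49000 nM

Compound 3 stands with the highest number of the three: its gap to compound 2 is within the scatter, while the step from compound 1 to compound 3 was a 5.5-fold higher number from compound 1 to compound 3 (0.74 log units; beyond the scatter). Compound 4 `COC(=O)c1sc2cc(C#Cc3ccc(F)cc3)cnc2c1N` differs from compound 3 by 4-fluorophenyl in place of 3-methoxyphenyl on a triple-bonded carbon. For the measured compounds named here, no measured step swaps one substituted phenyl for another; the nearest are a 5.5-fold higher number from compound 1 to compound 3 (0.74 log units; beyond the scatter) and a 2.0-fold higher number from compound 2 to compound 3 (0.30 log units; within the scatter), both running towards compound 3. A modest move back downward is therefore expected, as a 1.6-fold lower number from compound 3 to compound 4 (0.21 log units; within the scatter), with the weight of uncertainty on either side. Compound 4 is estimated at 30000 nM, between 10000 nM and 90000 nM.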

Compound 4, concentration for 50% growth inhibition: 24000 nM
Estimate against measurement, compound 4: 1.3-fold (0.10 log units) above; measured number inside the range.
By their numbers in this assay, from the lowest: compound 1; then compounds 4, 2 and 3 (each within the scatter of the next, the first and the last beyond it).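

For the compounds shown here, on the triple-bonded carbon, the change from 3-methoxyphenyl to 4-fluorophenyl gives the first comparison of one substituted phenyl with another in this assay (a 2.0-fold lower number from compound 3 to compound 4 (0.31 log units; beyond the scatter)). Thiophen-3-yl and 4-fluorophenyl cannot be told apart (a 1.0-fold lower number from compound 2 to compound 4 (0.01 log units; within the scatter)), whereas fluoro in place of amino on an aromatic carbon separates two otherwise matching compounds (a 2.7-fold higher number from compound 1 to compound 4 (0.43 log units; beyond the scatter)). Nothing given here explains these differences. The compounds shown leave open whether the gap between compound 3 and compound 4 follows the group or its placement on the phenyl, and whether a hydroxyl or dimethylamino group would match the amino group of compound 1.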